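The source may hold more compounds than are shown below. What is called first, only, known or untested is meant among the compounds shown, and "the series" means these compounds.

Of the compounds shown here, three that share one core have been measured in a functional assay on A549 cells (Homo sapiens) for antiproliferative activity, read by MTT assay; a lower number here means a stronger inhibitor, a higher number a weaker inhibitor. Compound 1 `Cc1ccccc1NC(=O)Nc1cccc(CNc2ncnc3ccccc23)c1` gives 40200 nM. Compound 2 `O=C(Nc1cccc(CNc2ncnc3ccccc23)c1)Nc1ccccc1F` gives 26100 nM. Compound 3 `O=C(Nc1cccc(CNc2ncnc3ccccc23)c1)Nc1ccccc1Cl` gives 18000 nM, the lowest number of the three. The step of a 2.2-fold lower number from compound 1 to compound 3 (0.35 log units; beyond the scatter) lies beyond the scatter, whereas a 1.5-fold lower number from compound 2 to compound 3 (0.16 log units; within the scatter) does not, so compound 3 cannot be called stronger than compound 2. The remaining step, a 1.5-fold lower number from compound 1 to compound 2 (0.19 log units; within the scatter), is also small.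

Compound 4 `O=C(Nc1ccc([N+](=O)[O-])cc1)Nc1cccc(CNc2ncnc3ccccc23)c1` has not yet been measured. Going from compound 3 to compound 4, the change is 4-nitrophenyl in place of 2-chlorophenyl on an amide-type nitrogen. The three measured steps each exchange one small group for another, methyl, fluoro or chloro on an aromatic carbon, and each produced at most a modest shift. Among the measured compounds shown here, the change to compound 4 is of a different kind, replacing the whole substituted phenyl group, and no measured step covers it directly. What the measured steps do show is that changes in this part of the molecule have so far shifted the number only modestly. For compound 4 a number near that of compound 3 is therefore expected, with wide uncertainty, which corresponds to a step of a 1.1-fold higher number from compound 3 to compound 4 (0.05 log units; within the scatter). The estimate for compound 4 in this assay is 20000 nM, with a range from 6000 nM to 60000 nM.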

Compound 4, half-maximal inhibitory concentration: > 50000 nM
Compound 4: only a limit was reported; the forecaster's own chance of this, stated with the estimate: 10%; middle value at least 2.5-fold (0.39 log units) away from the limit.
By their numbers in this assay, from the lowest: compounds 3, 2 and 1 (each within the scatter of the next, the first and the last beyond it). At a limit, above all of these: compound 4.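

In this assay, compound 4 sits at a limit and not at a number: the limit of > 50000 nM in this assay, at which 1 of the 4 values shown sits. Even so, putting 4-nitrophenyl in place of 2-chlorophenyl on an amide-type nitrogen gives an at least 2.7-fold higher number from compound 3 to compound 4 (0.44 log units; beyond the scatter), an at least modest step, which shows that this change can raise the number past the scatter. The other two steps, an at least 1.9-fold higher number from compound 2 to compound 4 (0.28 log units; that floor lies within the scatter) and an at least 1.2-fold higher number from compound 1 to compound 4 (0.09 log units; that floor lies within the scatter), cannot be read, as their floors lie within the scatter, so only compound 3 is separated from compound 4.

The change from 2-chlorophenyl to 4-nitrophenyl alters both the group and its place on the ring, and the compounds shown cannot separate those two contributions. They also leave open how this assay would read with an amine or a carboxylic acid on that phenyl ring, and how far the number for compound 4 lies past its limit.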